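Benzyl for tert-butyl ester, adenosine receptor A3 series

This account rests on a few compounds, and the source may have more. Where it says the series, first, only, none or still open, it means among the compounds named here.

Measured so far:
compound 1 `CC1=C(C(=O)OC(C)(C)C)C(c2cccs2)NC(=O)N1`: 7%
compound 2 `CC1=C(C(=O)OCc2ccccc2)C(c2cccs2)NC(=O)N1`: 8%
compound 3 `CC1=C(C(=O)OC(C)(C)C)C(c2ccco2)NC(=S)N1`: 9%

In an assay on membranes from HeLa cells for displacement of a labelled ligand from adenosine receptor A3 (Homo sapiens), read by scintillation counting, with a stated time of 180 min, tested at 1 uM (a lower number here means less inhibition, a higher number more inhibition at the concentration tested (going by the name of the read-out)), compound 1 gives 7% and compound 2 gives 8%. The change between them is benzyl in place of tert-butyl on an oxygen next to a carbonyl group, and the step is a number 1 percentage points higher from compound 1 to compound 2 (within the scatter). Compound 3 has the same atoms as compound 1, joined differently; the difference between the two cores is not broken down here. In this assay compound 3 gives 9%, within the scatter of the other two. Compound 4 `CC1=C(C(=O)OCc2ccccc2)C(c2ccco2)NC(=S)N1` is not yet measured and carries the same change as the earlier pair: benzyl in place of tert-butyl on an oxygen next to a carbonyl group, at the same place. The expected step is a number 1 percentage points higher from compound 3 to compound 4 (within the scatter), resting on the earlier step of a number 1 percentage points higher from compound 1 to compound 2 (within the scatter) lying within the scatter. Compound 4 is estimated at 10%, expected between 2% and 20%.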

Compound 4, a percentage reported as inhibition, at one concentration (the size of the read-out at that concentration, not a potency): 4%
Compound 4: middle estimate off by 6 percentage points, on the high side, within the range that was stated.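

On the core of compound 3, benzyl in place of tert-butyl on an oxygen next to a carbonyl group gives a number 5 percentage points lower from compound 3 to compound 4 (within the scatter) in this assay. Set beside the earlier step, the two cores show no difference: the same change on two cores in this assay, a number 1 percentage points higher (within the scatter) from compound 1 to compound 2 and a number 5 percentage points lower (within the scatter) from compound 3 to compound 4, 6 percentage points apart, within the scatter of two such steps

This shows that the change has no readable effect on either core at the concentration tested; it does not show that the change would carry over alike on a core with a larger read-out, and it gives no potency. The compounds shown leave open whether a longer chain on the ester oxygen, or a carboxylic acid or an amide in place of the ester, would move the read-out beyond the scatter. The difference between the two cores also remains unresolved.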